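This account rests on a few compounds, and the source may have more. Where it says the series, first, only, none or still open, it means among the compounds named here.

The compounds measured so far, each with its structure and its value in a functional assay on SW480 cells (Homo sapiens) for antiproliferative activity, read by MTT assay, with a stated time of 72 h; a higher number here means a weaker inhibitor, a lower number a stronger inhibitor:

compound 1, `CCOC(=O)c1cc(=O)c2cc(CSC(=S)N(C(C)C)C(C)C)ccc2o1`: > 25000 nM, which is a limit of the assay rather than a number
compound 2, `O=c1c(SC(=S)N2CCCC2)coc2ccc(Cl)cc12`: > 25000 nM, again a limit of the assay
compound 3, `Cc1ccc2c(=O)c(CSC(=S)N3CCOCC3)coc2c1`: 3800 nM

Compound 1 therefore stands at the limit of > 25000 nM in this assay, at which 2 of the 3 values shown sit, so its true potency is not known, only that it is weak. For the measured compounds named here, compound 3 is the one compound here with a measured number, and it carries a different core, so it gives no direct reading on the core of compound 1.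

Compound 4 is `CCOC(=O)c1cc(=O)c2cc(CSC(=S)N3CCCCC3)ccc2o1`. It differs from compound 1 in one place: piperidin-1-yl in place of diisopropylamino on a thiocarbonyl carbon. Going by the values given here, no pair of measured compounds isolates this change, so the size of the step can only be guessed. Since compound 1 sits at a limit, a move to a weaker compound could not be seen at all, while a move to a stronger one would have to be large to be seen. The step this estimate means, an at least 1.2-fold lower number from compound 1 to compound 4 (0.09 log units; that floor lies within the scatter), is expected to be modest and to stay close to the scatter. Compound 4 is estimated at 20000 nM, within a range from 5000 nM to 60000 nM.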

Compound 4, half-maximal inhibitory concentration: > 25000 nM
Compound 4: no number, only a limit (the forecaster's own chance of this, stated with the estimate: 55%); middle value at least 1.2-fold (0.09 log units) away from the limit.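

In this assay compound 4 gives > 25000 nM, which is a limit of the assay and not a number. Compound 1 also stands at a limit, so no step can be read from compound 1 to compound 4. The compounds shown leave open whether piperidin-1-yl in place of diisopropylamino on a thiocarbonyl carbon changes potency at all.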